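Compound 4: pyridin-3-yl replaced by 1-methyl-1H-imidazol-4-yl

The compounds below may be only part of what the source reports. "The series", "measured", "known", "first", "only" and "open" are said of these compounds alone.

Three compounds have so far been taken through a functional assay on SMMC-7721 cells (Homo sapiens) for inhibition, read by MTT assay, with a stated time of 48 h (a higher number here means a weaker inhibitor, a lower number a stronger inhibitor), in this series. Compound 1 (`COc1cc(NC(=O)Nc2ccncc2)cc(-c2cccnc2)c1OC`) gives 73600 nM in this read-out. Compound 3 (`O=C(Nc1cc(-c2cccnc2)cc(C(F)(F)F)c1)Nc1nccs1`) gives 68200 nM in the same read-out. These two values lie within the usual scatter of each other. From the compounds shown here alone, for compound 2 (`O=C(Nc1ccncc1)Nc1cc(-c2cccnc2)cc(C(F)(F)F)c1`) the entry reads "not determined" (no result reported): no result was reported for it, so its standing relative to compound 1 and compound 3 is unknown.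

Compound 4 (`Cn1cnc(-c2cc(NC(=O)Nc3ccncc3)cc(C(F)(F)F)c2)c1`) has not yet been measured. The structural change is 1-methyl-1H-imidazol-4-yl in place of pyridin-3-yl on an aromatic carbon and it sits on an aromatic carbon, meta to a trifluoromethyl group, with 1-methyl-1H-imidazol-4-yl in place of pyridin-3-yl. Going by the values given here, no measured pair shows a change of this kind, and the missing result for compound 2 leaves the step without a starting value. In this assay no step beyond the scatter is expected, in either direction. The nearest guide is compound 3 at 68200 nM for a compound that also carries the trifluoromethyl group. For compound 4 the estimated value is 65000 nM with an expected range of 25000 nM to 150000 nM in this read-out.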

Compound 4, half-maximal inhibitory concentration: 235000 nM
Beside the measured number, compound 4's estimate is 3.6-fold (0.56 log units) below it; the whole stated range lies below it.
By their numbers in this assay, from the lowest: compounds 3 and 1 (each within the scatter of the next); then compound 4.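

In this assay, going by these compounds alone, compound 4 gives 235000 nM and compound 2 has no number, so no step between these two compounds can be read. The compounds shown leave open what 1-methyl-1H-imidazol-4-yl in place of pyridin-3-yl does on its own to the read-out. No further data shown bear on this result.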